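Dimethylcarbamoyl in place of the sulfur group on the chain

The source may report more compounds than this note shows. Statements on the series, on what has been measured and on what is new or still open speak of the compounds shown alone.

In an assay on DDT1 cells (Cricetulus griseus) for binding affinity to adenosine receptor A1 (Homo sapiens), read by radioligand binding (on this read-out higher numbers stand for weaker inhibition and lower numbers for stronger inhibition), compound 1 `CC/N=C(\S)OC[C@H]1OC(n2cnc3c(NC4CCOC4)ncnc32)[C@H](O)[C@@H]1O` gives 33 nM. Compound 2 `CCC/N=C(\S)OC[C@H]1OC(n2cnc3c(NC4CCOC4)ncnc32)[C@H](O)[C@@H]1O` gives 50 nM in this assay. Within the data shown here, the one measured step, a 1.5-fold higher number from compound 1 to compound 2 (0.18 log units; within the scatter), is the exchange of methyl for hydrogen on a saturated chain carbon and stays within the scatter, so the number for compound 2 sits alongside that of compound 1 and neither can be ranked against the other.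

Compound 3 `CN(C)C(=O)OC[C@H]1OC(n2cnc3c(NC4CCOC4)ncnc32)[C@H](O)[C@@H]1O` is not yet measured. It differs from compound 2 by a group of 5 heavy atoms (3 carbon, 1 nitrogen, 1 oxygen; no ring) in place of a group of 6 heavy atoms (4 carbon, 1 nitrogen, 1 sulfur; no ring), on an oxygen on a saturated carbon. Among the measured compounds shown here, the step from compound 1 to compound 2 touches only a chain carbon and does not bear on a replacement of the whole group on the oxygen; no measured pair shows such a change. The expectation for compound 3 is therefore anchored on compound 2 with wide uncertainty, and a step of a 1.8-fold higher number from compound 2 to compound 3 (0.26 log units; within the scatter) toward a higher number is expected. Compound 3 is estimated at 90 nM in this assay, with a range from 20 nM to 400 nM.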

Compound 3, inhibition constant: 238 nM
The estimate for compound 3 lay 2.6-fold (0.42 log units) below the measured number; low and high end bracket the measured number.
By their numbers in this assay, from the lowest: compounds 1 and 2 (each within the scatter of the next); then compound 3.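

In this assay, exchanging the whole group on the oxygen on a saturated carbon moves the number beyond the scatter, with a 4.8-fold higher number from compound 2 to compound 3 (0.68 log units; beyond the scatter) and a 7.2-fold higher number from compound 1 to compound 3 (0.86 log units; beyond the scatter), whereas the chain change in a 1.5-fold higher number from compound 1 to compound 2 (0.18 log units; within the scatter) did not. The group on this oxygen is therefore not interchangeable for dimethylcarbamoyl in this assay, although the heavy-atom count hardly differs, and the higher number appears with the sulfur gone and the count of hydrogen-bond donors going from 1 to 0, two differences that arrive together and cannot be separated on these compounds. Nothing at hand bears on what lies behind the step.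

Open, going by these compounds, is whether an ethylcarbamoyl group, which would keep the ethyl chain of compound 1 and its nitrogen hydrogen while carrying oxygen in place of sulfur, would give a number closer to that of compound 1 or to that of compound 3. Also open, on these data alone, is whether a butyl chain on the double-bonded nitrogen would remain within the scatter of compound 1 and compound 2, since the chain has so far been varied only by one carbon.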